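Fluoro for carbamoyl on the fused ring of compound 1

The compounds below may be only part of what the source reports. "The series", "measured", "known", "first", "only" and "open" are said of these compounds alone.

The series shares a core carrying an ethyl-substituted lactam and a methylpyrazole; the compounds differ at the group attached to the two-carbon arm of the pyrimidine. Compound 1 `CCC1C(=O)N(C)c2cnc(-n3ccc4cc(C(N)=O)ccc43)nc2N1c1ccn(C)n1` bears a carbamoyl on a fused two-ring system. In a functional assay on A549 cells (Homo sapiens) for antiproliferative activity, read by CCK-8 assay, with a stated time of 72 h (on this read-out higher numbers stand for weaker inhibition of growth and lower numbers for stronger inhibition of growth), compound 1 gives 39500 nM. Compound 2 `CCC1C(=O)N(C)c2cnc(Nc3ccc(S(=O)(=O)NCC(C)C)cc3)nc2N1c1ccn(C)n1` carries an aniline with a sulfonamide; in this assay compound 2 gives 31600 nM, which lies within the usual scatter of the number for compound 1, so the two cannot be ordered. Compound 3 `CCC1C(=O)N(C)c2cnc(Nc3ccc(S(=O)(=O)NCCO)cc3)nc2N1c1ccn(C)n1`, with a hydroxyethyl sulfonamide, is reported in this assay as "not active" (no number reported), with no number given. Going by the values given here, only two numbers exist, and both are weak.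

Compound 4 `CCC1C(=O)N(C)c2cnc(-n3ccc4cc(F)ccc43)nc2N1c1ccn(C)n1` is the next compound to be measured. It differs from compound 1 in one place: fluoro in place of carbamoyl on an aromatic carbon. Among the compounds with values here, no step between measured compounds bears on this change, so nothing in the data says which way it should go. Given that compound 1 sits at 39500 nM and that no measured pair guides the change, the step of a 1.1-fold higher number from compound 1 to compound 4 (0.06 log units; within the scatter) is expected to be small, not clearly beyond the scatter, with a lean toward weaker inhibition. Compound 4 is therefore estimated at 45000 nM in this assay, with a range from 15000 nM to 130000 nM.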

Compound 4, concentration for 50% growth inhibition: "not active" (no number reported)
The entry for compound 4 holds no number; there is nothing to compare the estimate with.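

In this assay, going by these compounds alone, compound 4 is reported as not active with no number, so no step from compound 1 to compound 4 can be read. Nothing shown here offers an explanation for this result.

The compounds shown leave open how far compound 1 at 39500 nM stands from compound 4, so the effect of fluoro in place of carbamoyl remains unsized.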